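The compounds below may be only part of what the source reports. "The series", "measured", "known", "first", "only" and "open" are said of these compounds alone.

Compound 1 `CN(C)c1ccc(C#Cc2c(F)cccc2F)nc1`: 85.2%
Compound 2 `Fc1cccc(F)c1C#Cc1ccc2[nH]ccc2c1`: 91.5%

In a functional assay on LS174T cells (Homo sapiens) for inhibition, with a stated time of 4 days, tested at 10 uM (on this read-out higher numbers stand for a stronger effect at the one concentration tested and lower numbers for a weaker effect), compound 1 gives 85.2%, and compound 2 gives 91.5%. Compound 2 holds the higher of the two numbers, but its gap to compound 1 lies within the scatter, so neither can be set above the other. Compound 3 `Cn1ccc2cc(C#Cc3c(F)cccc3F)ccc21` differs from compound 2 by methyl in place of hydrogen on an aromatic nitrogen. Within the data shown here, no measured pair shows this change, so the step can only be expected rather than read off. The expected step of a number 7.5 percentage points lower from compound 2 to compound 3 (within the scatter) is a small downward one, likely not beyond the scatter. Compound 3 is therefore estimated to give 84%, within 62% to 97%.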

Compound 3, a percentage reported as inhibition, at one concentration (the size of the read-out at that concentration, not a potency): 95.2%
The estimate for compound 3 lay 11.2 percentage points below the measured number; measured number inside the range.
By their numbers in this assay, from the lowest: compounds 1, 2 and 3 (each within the scatter of the next).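

In this assay, methyl in place of hydrogen on an aromatic nitrogen gives a number 3.7 percentage points higher from compound 2 to compound 3 (within the scatter) and so produces no change that can be told from scatter. At the one concentration tested, this position therefore accepts the methyl, and the hydrogen on this nitrogen is not shown to be needed for the effect. No measured property bears on this result, and nothing here explains it.

Going by these compounds, whether a longer chain, a carboxylic acid or an amine on this nitrogen would keep the effect remains open. The single concentration also leaves open how the effects of compound 2 and compound 3 compare at other concentrations.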